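The source may report more compounds than this note shows. Statements on the series, on what has been measured and on what is new or still open speak of the compounds shown alone.

Measured so far in a functional assay on MCF7 cells (Homo sapiens) for antiproliferative activity, read by MTT assay, with a stated time of 72 h; on this read-out higher numbers stand for weaker inhibition and lower numbers for stronger inhibition:
- compound 1 (`O=S(=O)(Oc1ccc(Cl)cc1)C1CC2OC1C(c1ccc(/C=C/c3cc(O)cc(O)c3)cc1)=C2c1ccc(O)cc1`) gives 17900 nM
- compound 2 (`O=S(=O)(Oc1cccc(Br)c1)C1CC2OC1C(c1ccc(/C=C/c3cc(O)cc(O)c3)cc1)=C2c1ccc(O)cc1`) gives 19800 nM

Going by the values given here, with only two numbers available, compound 2 stands level with compound 1. The next structure is compound 3 (`O=S(=O)(Oc1cccc2ccccc12)C1CC2OC1C(c1ccc(/C=C/c3cc(O)cc(O)c3)cc1)=C2c1ccc(O)cc1`), and the change is naphthalen-1-yl in place of 3-bromophenyl on an oxygen, with naphthalen-1-yl in place of 3-bromophenyl on an oxygen. Among the compounds with values here, only one measured step bears on this, a swap of the group on that same oxygen, and it stayed within the scatter: a 1.1-fold higher number from compound 1 to compound 2 (0.04 log units; within the scatter). That step did not test a second aromatic ring, so the evidence is thin. No shift beyond the scatter is expected in this assay, and the estimated step is a 1.2-fold lower number from compound 2 to compound 3 (0.07 log units; within the scatter). Compound 3 is estimated at 17000 nM, with an expected range of 8000 nM to 36000 nM.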

Compound 3, half-maximal inhibitory concentration: 11000 nM
For compound 3 the middle estimate is 1.5-fold (0.19 log units) above the measured one; low and high end bracket the measured number.
By their numbers in this assay, from the lowest: compounds 3, 1 and 2 (each within the scatter of the next).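

In this assay, replacing the single aromatic ring on the oxygen bound to the sulfonyl sulfur with the two-ring naphthalen-1-yl group gives a 1.8-fold lower number from compound 2 to compound 3 (0.26 log units; within the scatter) and a 1.6-fold lower number from compound 1 to compound 3 (0.21 log units; within the scatter). Adding a second aromatic ring at this position, a larger change than the earlier swap of halogen-bearing rings, therefore produces no shift beyond the scatter. No measured evidence accounts for this result. The compounds shown leave open whether a ring carrying an amine or a carboxylic acid, or a straight alkyl chain in place of the ring, would move the number beyond the scatter.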